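Losing the 3-(dimethylamino)propyl chain of compound 1

The source may hold more compounds than are shown below. What is called first, only, known or untested is meant among the compounds shown, and "the series" means these compounds.

Measured so far in an ADME assay on Vero cells (Chlorocebus sabaeus) for cytotoxicity, read by crystal violet staining; on this read-out lower numbers stand for higher toxicity in this test and higher numbers for lower toxicity in this test:
Compound 1 `CN(C)CCCN(/N=N/c1ccccc1)c1cccc(C(F)(F)F)c1` gives 20000 nM
Compound 2 `CN(C)CCCN(/N=N/c1ccccc1)c1ccccc1` gives 35000 nM

In this assay, among the measured compounds shown here, only two numbers are known, and they lie close together, with a 1.8-fold higher number from compound 1 to compound 2 (0.24 log units; within the scatter) as the single measured step. Compound 1 therefore stands level with compound 2, within the scatter, and neither can be ranked above the other.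

The next compound is compound 3 `FC(F)(F)c1cccc(N/N=N/c2ccccc2)c1`, which departs from compound 1 at a different place. The difference is hydrogen in place of 3-(dimethylamino)propyl on a nitrogen on an aromatic ring. For the measured compounds named here, the one measured step, a 1.8-fold higher number from compound 1 to compound 2 (0.24 log units; within the scatter), concerns trifluoromethyl on an aromatic carbon and does not touch this nitrogen. Going by the values given here, no measured pair shows what happens when the chain is lost, so the data give no direction for this change, and any expectation stays loose. An estimated 1.3-fold higher number from compound 1 to compound 3 (0.10 log units; within the scatter) is expected, with the wide range carrying the uncertainty. The estimate for compound 3 is 25000 nM (expected range 7000 nM to 90000 nM).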

Compound 3, half-maximal cytotoxic concentration: 15000 nM
Beside the measured number, compound 3's estimate is 1.7-fold (0.22 log units) above it, within the range that was stated.
By their numbers in this assay, from the lowest: compounds 3, 1 and 2 (each within the scatter of the next, the first and the last beyond it).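

In this assay, the nitrogen on an aromatic ring now has a measured step of its own: hydrogen in place of 3-(dimethylamino)propyl gives a 1.3-fold lower number from compound 1 to compound 3 (0.12 log units; within the scatter). Compound 3 thus stands level with compound 1, so removing this chain of 6 heavy atoms, with its nitrogen, produces no shift beyond the scatter, and the earlier step at the trifluoromethyl group could not show this. No supporting measurement bears on this result.

The compounds shown leave open whether other groups on this nitrogen, such as a methyl group, a longer chain ending in a dimethylamino group or a chain ending in a carboxylic acid, would also stay level with compound 1. They also leave open whether hydrogen in place of 3-(dimethylamino)propyl would give a similar step in compound 2, where hydrogen stands in place of the trifluoromethyl group, or in an analogue carrying a nitrile there.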